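Dichlorobenzyl replacing tert-butylbenzyl on the indole nitrogen

The compounds below may be only part of what the source reports. "The series", "measured", "known", "first", "only" and "open" are said of these compounds alone.

Compound 3 `CCN(CC)Cc1ccc2nc(NC(=O)N/N=C/c3cn(Cc4ccc(C(C)(C)C)cc4)c4ccccc34)sc2c1` gives 2120 nM in a functional assay on MDA-MB-231 cells (Homo sapiens) for cytotoxicity, read by MTT assay, with a stated time of 72 h (on this read-out higher numbers stand for weaker inhibition and lower numbers for stronger inhibition), the highest of the three numbers; compound 2 `CCN(CC)Cc1ccc2nc(NC(=O)N/N=C/c3cn(Cc4cccc(Cl)c4)c4ccccc34)sc2c1` gives 2050 nM, and the two differ only by a 1.0-fold higher number from compound 2 to compound 3 (0.01 log units; within the scatter), while compound 1 `CCN(CC)Cc1ccc2nc(NC(=O)N/N=C/c3cn(Cc4ccccc4Cl)c4ccccc34)sc2c1` gives 900 nM, with a 2.4-fold higher number from compound 1 to compound 3 (0.37 log units; beyond the scatter) and a 2.3-fold higher number from compound 1 to compound 2 (0.36 log units; beyond the scatter). Compound 4 `CCN(CC)Cc1ccc2nc(NC(=O)N/N=C/c3cn(Cc4ccc(Cl)c(Cl)c4)c4ccccc34)sc2c1` carries the change (3,4-dichlorophenyl in place of 4-(tert-butyl)phenyl on a saturated chain carbon bound to an aromatic nitrogen). Among the measured compounds shown here, the only step that bears on it directly is the exchange of 3-chlorophenyl for 4-(tert-butyl)phenyl between compound 2 and compound 3, which stayed within the scatter; no measured compound shows a second chlorine at the 4-position, so no step reports its effect. Compound 4 is therefore expected to give about 1600 nM (range 800 nM to 3200 nM), a step of a 1.3-fold lower number from compound 3 to compound 4 (0.12 log units; within the scatter) that is expected to stay within the scatter.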

Compound 4, half-maximal inhibitory concentration: 4490 nM
For compound 4 the middle estimate is 2.8-fold (0.45 log units) below the measured one; the measured number lies above the stated range.
By their numbers in this assay, from the lowest: compound 1; then compounds 2 and 3 (each within the scatter of the next); then compound 4.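

Adding a second chlorine to the benzyl on the indole nitrogen did not strengthen inhibition: chloro in place of hydrogen gave a 2.2-fold higher number from compound 2 to compound 4 (0.34 log units; beyond the scatter), so the 3,4-dichlorobenzyl is less favourable here than a single chlorine. It also separated from the 4-(tert-butyl)benzyl, with a 2.1-fold higher number from compound 3 to compound 4 (0.33 log units; beyond the scatter), and the range at this position widened to a 5.0-fold higher number from compound 1 to compound 4 (0.70 log units; beyond the scatter), making compound 4 the weakest of the four. No evidence is available to explain these differences. The compounds shown leave open how an unsubstituted benzyl, or a benzyl carrying a methoxy group or an amine, would read in this assay.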